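The compounds below may be only part of what the source reports. "The series", "measured", "known", "first", "only" and "open" are said of these compounds alone.

Measured so far in an assay on HEK293 cells for displacement of a labelled ligand from corticotropin-releasing factor receptor 1 (Homo sapiens), read by scintillation proximity assay, with a stated time of 2 h; on this read-out higher numbers stand for weaker inhibition and lower numbers for stronger inhibition:
compound 1 `COCc1cc(OC)c(-c2csc3c(N(CC4CCOCC4)CC4CC4)c(C)nn23)c(OC)c1` gives 46 nM
compound 2 `COCc1cc(OC)c(-c2csc3c(N(CC4CCOCC4)CC4CC4)c(OC)nn23)c(OC)c1` gives 69 nM
compound 3 `CCN(c1c(OC)nn2c(-c3c(OC)cc(COC)cc3OC)csc12)C1CCOCC1` gives 147 nM

Compound 3 stands highest of the three numbers in this assay; compound 2 is nearest and compound 1 furthest, both lower and both beyond the scatter.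

Compound 4 `COCc1cc(OC)c(-c2csc3c(N(CCC4CC4)C4CCOCC4)c(OC)nn23)c(OC)c1` is compound 3 with cyclopropyl in place of hydrogen on a saturated chain carbon, two bonds along the chain from a nitrogen on an aromatic ring. Going by the values given here, the one measured step, a 1.5-fold higher number from compound 1 to compound 2 (0.18 log units; within the scatter), concerns the methoxy for methyl on the aromatic carbon and does not touch the chain on the nitrogen, so no measured step bears directly on the change from compound 3 to compound 4. Compound 1 and compound 2 both carry a cyclopropyl in a chain on the same nitrogen and both give lower numbers than compound 3, but each differs from compound 3 at more than one place, so their values show only that a cyclopropyl-bearing chain on that nitrogen has gone with lower numbers. For compound 4 a modest move toward lower numbers is expected, a 1.6-fold lower number from compound 3 to compound 4 (0.21 log units; within the scatter), with wide uncertainty. The estimate for compound 4 in this assay is 90 nM, within 30 nM to 270 nM.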

Compound 4, half-maximal inhibitory concentration: 83 nM
Compound 4: the middle estimate sits 1.1-fold (0.04 log units) above what was measured, within the range that was stated.
By their numbers in this assay, from the lowest: compounds 1, 2, 4 and 3 (each within the scatter of the next, the first and the last beyond it).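

In this assay, going by these compounds alone, the change from ethyl to 2-cyclopropylethyl gives a 1.8-fold lower number from compound 3 to compound 4 (0.25 log units; within the scatter), the first direct reading of cyclopropyl in place of hydrogen on a saturated chain carbon, two bonds along the chain from a nitrogen on an aromatic ring. The cyclopropyl, with its 3 heavy atoms, is therefore accepted at this place, with no shift that stands clear of the scatter, though this rests on a single pair and supports no wider pattern. No measurement of any other kind bears on this step.

The compounds shown leave open whether a longer chain, a phenyl ring, an amine or a carboxylic acid would be accepted at this chain carbon as the cyclopropyl is. Also open, on these data alone, is whether the same change reads alike with methyl in place of methoxy on the aromatic carbon.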